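A few compounds are considered here, and "the series" means these few. Any claim that something is new, unique, unknown or untested is made for them only; others in the source may bear on it.

Going by the values given here, in a functional assay on SW-620 cells (Homo sapiens) for antiproliferative activity, read by MTT assay, with a stated time of 48 h (a higher number here means a weaker inhibitor, a lower number a stronger inhibitor), two compounds have numbers so far. Compound 1 (`CCCc1nc2cc(C(=O)N3CCC4(CC3)CC(=O)N(c3ccc(C(F)(F)F)cc3)C4)cc(C)c2[nH]1`) gives 1820 nM and compound 2 (`O=C(c1ccc2[nH]c(-c3ccccc3)nc2c1)N1CCC2(CC1)CC(=O)N(c1ccc(C(F)(F)F)cc1)C2`) gives 2050 nM, so compound 2 stands level with compound 1 within the scatter. Next in line is compound 3 (`CC(C)c1ccc(-c2nc3cc(C(=O)N4CCC5(CC4)CC(=O)N(c4ccc(C(F)(F)F)cc4)C5)ccc3[nH]2)cc1`), which differs from compound 2 in one place: isopropyl in place of hydrogen on an aromatic carbon. In words, this is isopropyl in place of hydrogen on an aromatic carbon, or phenyl to 4-isopropylphenyl. Among the compounds with values here, no measured pair differs in one place, so the size of this change has no direct precedent. A step beyond the scatter in this assay is not expected, though a slight move toward a lower number is possible. The expected change is a 1.3-fold lower number from compound 2 to compound 3 (0.11 log units; within the scatter). For compound 3 the estimated value is 1600 nM, with an expected range of 700 nM to 3800 nM.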

Compound 3, half-maximal inhibitory concentration: > 10000 nM
Compound 3 ended at the assay's limit; the forecaster's own chance of this, stated with the estimate: 3%; at least 6.2-fold (0.79 log units) between middle value and limit.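

In this assay compound 3 gives > 10000 nM, a limit of the assay and not a number. Phenyl to 4-isopropylphenyl is the first one-place change in the series, and it gives an at least 4.8-fold higher number from compound 2 to compound 3 (0.68 log units; beyond the scatter), so this aromatic carbon, para to a large group, is not indifferent to substitution in this assay. The step has a lower bound only, and its true size stays unknown: the limit of > 10000 nM in this assay, at which 1 of the 3 values shown sits.

The compounds shown hold only hydrogen and isopropyl at this carbon, so they leave open whether the weaker result belongs to isopropyl alone or to any group placed there. A methyl, a fluorine, a methoxy or a carboxylic acid at the same carbon would begin to separate these readings.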